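Fluoro in Place of Hydrogen on Compound 2

A few compounds are considered here, and "the series" means these few. Any claim that something is new, unique, unknown or untested is made for them only; others in the source may bear on it.

In a functional assay on A549 cells (Homo sapiens) for antiproliferative activity, read by MTT assay, with a stated time of 48 h (on this read-out higher numbers stand for weaker inhibition and lower numbers for stronger inhibition), compound 1 (`COc1ccc(-c2cncc3[nH]c(=O)n(Cc4cc(OC)c(OC)c(OC)c4)c23)cc1O`) gave > 20000 nM, which is a limit and not a number.

Going by the values given here, compound 2 (`COc1ccc(-c2cc3c(cn2)[nH]c(=O)n3-c2cc(OC)c(OC)c(OC)c2)cc1`) gave 1120 nM, the only actual number available so far, so it stands without a numerical comparison.

Compound 3 (`COc1ccc(-c2cc3c(cn2)[nH]c(=O)n3-c2cc(OC)c(OC)c(OC)c2)cc1F`) has not yet been measured and differs from compound 2 in one place: fluoro in place of hydrogen on an aromatic carbon. The change turns 4-methoxyphenyl into 3-fluoro-4-methoxyphenyl, with fluoro in place of hydrogen on an aromatic carbon, ortho to a methoxy group and meta to a large group.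

Among the compounds with values here, no measured pair of compounds shows what this change does, so the expectation rests only on its small size. A modest step in this assay is expected, most likely no larger than the usual scatter, with at most a slight lean toward stronger inhibition.

The estimated change is a 1.2-fold lower number from compound 2 to compound 3 (0.09 log units; within the scatter).

The expected value for compound 3 is 900 nM, with an estimated range of 280 nM to 3200 nM.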

Compound 3, half-maximal inhibitory concentration: 2020 nM
The estimate for compound 3 lay 2.2-fold (0.35 log units) below the measured number; low and high end bracket the measured number.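

In this assay, going by these compounds alone, compound 2 and compound 3 form the first measured pair that differs in one place, and the reading is a 1.8-fold higher number from compound 2 to compound 3 (0.26 log units; within the scatter). On this read-out, fluoro in place of hydrogen on an aromatic carbon, ortho to a methoxy group and meta to a large group, leaves the two compounds indistinguishable, and this single pair shows neither a gain nor a loss from the change. The one limit among the values shown belongs to compound 1 and plays no part in this step: the limit of > 20000 nM in this assay, at which 1 of the 3 values shown sits.

The compounds shown leave open whether a different group at this same place, such as chloro, trifluoromethyl, hydroxyl or an amine, would produce a step beyond the scatter, as one small substituent is all that can be compared here. Within the data shown here, it also remains open whether fluoro would read the same way on the core of compound 1, which differs from compound 2 in more than one place and so forms no comparable pair with it.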